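A few compounds are considered here, and "the series" means these few. Any claim that something is new, unique, unknown or untested is made for them only; others in the source may bear on it.

In a functional assay on K562 cells (Homo sapiens) for cytotoxicity, read by trypan blue exclusion, with a stated time of 96 h (on this read-out higher numbers stand for weaker inhibition and lower numbers for stronger inhibition), the measured compounds read as follows:

- Compound 1 `COc1cc(OC)c(/C=C/S(=O)(=O)Nc2ccc(OC)c(OP(=O)(O)O)c2)c(OC)c1`: 7.5 nM
- Compound 2 `COC(=O)CNc1cc(NS(=O)(=O)/C=C/c2c(OC)cc(OC)cc2OC)ccc1OC`: 350 nM
- Compound 3 `COC(=O)C(Nc1cc(NS(=O)(=O)/C=C/c2c(OC)cc(OC)cc2OC)ccc1OC)c1ccc(Br)cc1`: 1000 nM

Compound 3 has the highest number of the three, so it is the weakest inhibitor in this small set. Compound 4 `COc1cc(OC)c(/C=C/S(=O)(=O)Nc2ccc(OC)c(NCC(=O)O)c2)c(OC)c1` has not yet been measured. It differs from compound 3 as follows: carboxymethyl in place of (4-bromophenyl)(methoxycarbonyl)methyl on a nitrogen on an aromatic ring.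

For the measured compounds named here, two measured steps bear on this change. Compound 4 lacks the 4-bromophenyl, whose addition gave a 2.9-fold higher number from compound 2 to compound 3 (0.46 log units; beyond the scatter), a modest step. Going by the values given here, no measured step isolates the loss of methoxycarbonyl, so that part remains uncertain. Among the compounds with values here, the only hint comes from compound 1, which has no methoxycarbonyl either, and the change to the chain of compound 2 gave a 47-fold higher number from compound 1 to compound 2 (1.67 log units; beyond the scatter), a large step. A clear move toward stronger inhibition is therefore expected, larger than the 4-bromophenyl step alone, with an estimated size of a 17-fold lower number from compound 3 to compound 4 (1.22 log units; beyond the scatter). Compound 4 is estimated at 60 nM, with an expected range of 12 nM to 300 nM.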

Compound 4, half-maximal inhibitory concentration: 20 nM
For compound 4 the middle estimate is 3.0-fold (0.48 log units) above the measured one; the measured number falls inside the stated range.
By their numbers in this assay, from the lowest: compound 1; then compound 4; then compound 2; then compound 3.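

Exchanging only the methyl of the ester for hydrogen gives an 18-fold lower number from compound 2 to compound 4 (1.24 log units; beyond the scatter) in this assay and shows that, on the nitrogen on an aromatic ring, the free carboxylic acid of carboxymethyl counts for far more than the modest 4-bromophenyl step suggested. Most of the whole change of a 50-fold lower number from compound 3 to compound 4 (1.70 log units; beyond the scatter) therefore traces to that ester methyl and not to the 4-bromophenyl. Carboxymethyl also comes close to the group carried by compound 1 without matching it, with a 2.7-fold higher number from compound 1 to compound 4 (0.43 log units; beyond the scatter) still lying beyond the scatter.

Going by these compounds, what stays open is whether a primary amide, a tetrazole or a longer chain ending in a carboxylic acid on that nitrogen would hold this level, and what 4-bromophenyl costs when the acid is free. Nothing measured here gives a reason for these steps.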